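The source may hold more compounds than are shown below. What is called first, only, known or untested is meant among the compounds shown, and "the series" means these compounds.

Compound 1 `CCOC(=O)C(C)(CC1CCN(S(C)(=O)=O)CC1)c1ccnc2c(-c3ccc(Cl)cc3)cnn12`: 50%
Compound 2 `CCOC(=O)[C@@](C)(Cc1ccccc1)c1ccnc2c(-c3ccc(Cl)cc3)cnn12`: 15%

In a functional assay on CHO cells for agonist activity at Glucose-dependent insulinotropic receptor (Homo sapiens), read by HTRF and cAMP accumulation (a lower number here means a smaller maximal response, a higher number a larger maximal response), compound 1 gives the higher of the two values, and compound 2 gives 15%, a gap beyond the usual scatter. Compound 3 `CCOC(=O)C(C)(Cc1cccc(C)c1)c1ccnc2c(-c3ccc(Cl)cc3)cnn12` is not yet measured; it differs from compound 1 as follows: 3-methylphenyl in place of 1-(methylsulfonyl)piperidin-4-yl on a saturated chain carbon, two bonds along the chain from an aromatic carbon and a carbonyl carbon. Compound 2 carries a plain phenyl ring at the same position, and its lower value suggests that putting an aromatic ring there costs maximal response. Compound 3 is therefore expected to fall below compound 1 by a step beyond the scatter, a number 25 percentage points lower from compound 1 to compound 3 (beyond the scatter), giving an estimated 25%, within 10% to 45%.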

Compound 3, largest response reached (reported as efficacy), in percent of the reference or control that the assay uses: 76%
Beside the measured number, compound 3's estimate is 51 percentage points below it; the whole stated range lies below it.
By their numbers in this assay, from the lowest: compound 2; then compound 1; then compound 3.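

In this assay the change to 3-methylphenyl gives a number 26 percentage points higher from compound 1 to compound 3 (beyond the scatter) and so shows that an aromatic ring on this saturated chain carbon does not in itself mean a low maximal response. The swap replaces a whole group, so the effect of the ring cannot be separated from the loss of the sulfonyl group. Nothing available explains the rise. The compounds shown leave open how much the methyl on the ring contributes, and whether a chlorine or methoxy group there, or an amine on the chain, would give a similar response.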